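A few compounds are considered here, and "the series" means these few. Any claim that something is new, unique, unknown or untested is made for them only; others in the source may bear on it.

Measured so far in a functional assay on A549 cells (Homo sapiens) for antiproliferative activity, read by MTT assay, with a stated time of 48 h; a higher number here means a weaker inhibitor, a lower number a stronger inhibitor:
- compound 1 `CCCC(C)Oc1ccc(C(=O)/C=C/c2c(/C=C/c3ccc(OC)cc3)cc(OC)cc2OC)cc1`: 9.4 ug/mL
- compound 2 `COc1ccc(/C=C/c2cc(OC)cc(OC)c2/C=C/C(=O)c2cccc(Cl)c2)cc1`: 5.6 ug/mL
- compound 3 `COc1ccc(/C=C/c2cc(OC)cc(OC)c2/C=C/C(=O)c2ccc(C(F)(F)F)cc2)cc1`: 7.8 ug/mL

Compound 3 is not separated from the other two compounds: a 1.2-fold lower number from compound 1 to compound 3 (0.08 log units; within the scatter) and a 1.4-fold higher number from compound 2 to compound 3 (0.14 log units; within the scatter) both lie within the scatter. The next compound is compound 4 `COc1ccc(/C=C/c2cc(OC)cc(OC)c2/C=C/C(=O)c2ccc(N)cc2)cc1`, which has amino in place of trifluoromethyl on an aromatic carbon, para to a large group: amino in place of trifluoromethyl on an aromatic carbon. The closest measured change is a 1.2-fold lower number from compound 1 to compound 3 (0.08 log units; within the scatter), which also swaps one group on an aromatic carbon. The swaps of the whole aryl group on the carbonyl carbon, a 1.7-fold lower number from compound 1 to compound 2 (0.22 log units; within the scatter) and a 1.4-fold higher number from compound 2 to compound 3 (0.14 log units; within the scatter), also bear on it, and these too stay within the scatter. Within the data shown here, no measured compound carries an amino group, so the data give no direction for this change. No step beyond the scatter is therefore expected in this assay. The expected step is a 1.1-fold lower number from compound 3 to compound 4 (0.05 log units; within the scatter). For compound 4 the estimated value is 7 ug/mL, with an expected range of 3 ug/mL to 16 ug/mL.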

Compound 4, half-maximal inhibitory concentration: 3.8 ug/mL
For compound 4 the middle estimate is 1.8-fold (0.27 log units) above the measured one; measured number inside the range.
By their numbers in this assay, from the lowest: compounds 4, 2, 3 and 1 (each within the scatter of the next, the first and the last beyond it).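

At the aromatic carbon para to a large group, amino in place of trifluoromethyl gives a modest step in this assay that, unlike every earlier step, lies beyond the scatter (a 2.1-fold lower number from compound 3 to compound 4 (0.31 log units; beyond the scatter)). Amino in place of 1-methylbutoxy at the same carbon also clears the scatter (a 2.5-fold lower number from compound 1 to compound 4 (0.39 log units; beyond the scatter)), whereas 4-aminophenyl in place of 3-chlorophenyl does not (a 1.5-fold lower number from compound 2 to compound 4 (0.17 log units; within the scatter)), so compound 4 separates from compound 1 and compound 3 but not from compound 2. No measurement shown accounts for these steps.

On these data alone, whether the lower number is specific to amino remains open, and a hydroxyl, a methylamino or an acetamido group at this carbon would test that. Plain phenyl in place of 4-aminophenyl would give the baseline for this position.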